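A second chloro group on compound 2

A few compounds are considered here, and "the series" means these few. Any claim that something is new, unique, unknown or untested is made for them only; others in the source may bear on it.

In a physicochemical assay for solubility, at pH 1.1 (a lower number here means a less soluble compound, a higher number a more soluble compound), compound 1 (`CCN(Cc1ccc(OCCn2c(=O)ccn(C)c2=O)c(C)c1)C(CC(=O)O)c1ccc(Cl)cc1`) gives 3000000 nM and compound 2 (`COc1cc(CN(CC(C)C)C(CC(=O)O)c2ccc(Cl)cc2)ccc1OCCN1C(=O)CCC1=O`) stands level with it at 3000000 nM on the numbers shown. Compound 3 (`COc1cc(CN(CC(C)C)C(CC(=O)O)c2ccc(Cl)cc2Cl)ccc1OCCN1C(=O)CCC1=O`) carries chloro in place of hydrogen on an aromatic carbon, ortho to a large group and meta to a chloro group, so that 4-chlorophenyl becomes 2,4-dichlorophenyl (chloro in place of hydrogen on an aromatic carbon). Within the data shown here, no measured pair of compounds shows this change. A small fall in this assay is expected, or nothing beyond the scatter. The expected step (a 1.5-fold lower number from compound 2 to compound 3 (0.18 log units; within the scatter)) is therefore modest. Compound 3 is estimated at 2000000 nM (range 700000 nM to 3500000 nM).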

Compound 3, solubility: 3000000 nM
The estimate for compound 3 lay 1.5-fold (0.18 log units) below the measured number; the measured number falls inside the stated range.
By their numbers in this assay, from the lowest: compounds 1, 2 and 3 (each within the scatter of the next).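

Among these compounds, the change from 4-chlorophenyl to 2,4-dichlorophenyl gives the first step in one place in this assay (no change at the digits printed from compound 2 to compound 3 (within the scatter)). Chloro in place of hydrogen at this position, ortho to a large group and meta to a chloro group, therefore leaves the read-out where compound 2 stood. Nothing measured here gives a reason for this. Open, from the compounds shown here alone, is whether a fluoro group, a methoxy group or an amine at this position would read the same, and whether chloro there would give the same step on the core of compound 1.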